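Aryl alkyl chain length and cytotoxicity: heptyl to pentyl

This account rests on a few compounds, and the source may have more. Where it says the series, first, only, none or still open, it means among the compounds named here.

Three compounds share one core and differ only in the length of the straight alkyl chain on the aryl ring. Compound 1 `CCCc1ccc(-c2cc3cn([C@H]4C[C@H](O)[C@@H](CO)O4)c(=O)nc3s2)cc1` carries the propyl chain. In a functional assay on HeLa cells (Homo sapiens) for cytotoxicity (on this read-out higher numbers stand for lower toxicity in this test and lower numbers for higher toxicity in this test), compound 1 gives > 200000 nM, which is a limit of the test and not a number. Compound 2 `CCCCCCCc1ccc(-c2cc3cn([C@H]4C[C@H](O)[C@@H](CO)O4)c(=O)nc3s2)cc1` carries the heptyl chain. In this assay compound 2 gives > 200000 nM, likewise a limit and not a number. The step that the two limits leave unreadable from compound 1 to compound 2 is therefore of unknown size, since both values sit at the limit of > 200000 nM in this assay, at which 2 of the 2 values shown sit. Compound 2 thus stands at the limit, with no toxicity read within the tested range.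

Compound 3 `CCCCCc1ccc(-c2cc3cn([C@H]4C[C@H](O)[C@@H](CO)O4)c(=O)nc3s2)cc1` is not yet measured. It differs from compound 2 by hydrogen in place of ethyl on a saturated chain carbon, five bonds along the chain from an aromatic carbon. Among the measured compounds shown here, the only measured step that bears on chain length is the one from the propyl to the heptyl chain, and it is unreadable. Compound 3 falls between the two measured chain lengths, both of which sit at the limit, so the step of a number no higher from compound 2 to compound 3 (the limit leaves the size open) is expected to be none beyond the scatter, most likely another limit. Compound 3 is estimated at 200000 nM, with a range of 100000 nM to 400000 nM in this assay.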

Compound 3, half-maximal cytotoxic concentration: > 200000 nM
Compound 3: a limit, no number (the forecaster's own chance of this, stated with the estimate: 85%); the middle value sits exactly at the limit.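

Compound 3 gives > 200000 nM in this assay as a limit and not a number. No step among compound 1, compound 2 and compound 3 can be read: the limit of > 200000 nM in this assay, at which 3 of the 3 values shown sit.

The compounds shown leave open whether any of the propyl, pentyl or heptyl chains gives a cytotoxic concentration within the tested range, and how these chains would rank.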